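The source may hold more compounds than are shown below. What is called first, only, known or untested is meant among the compounds shown, and "the series" means these compounds.

Measured in a functional assay on A549 cells (Homo sapiens) for antiproliferative activity, read by MTT assay, with a stated time of 72 h; a lower number here means a stronger inhibitor, a higher number a weaker inhibitor:

Compound 1, `COc1cc2c(Nc3ccc(C#N)cc3)ncnc2cc1OCCCN(C)C`, gives 60500 nM.
Compound 2, `COc1cc2c(Nc3ccc(C#N)cc3)ncnc2cc1OCCCN1CCCC1`, gives 21800 nM.
Compound 3, `COc1cc2c(Nc3ccc(C#N)cc3)ncnc2cc1OCCCN1CCC(CO)CC1`, gives only a limit of the assay, > 100000 nM.

Of the two numbers that were obtained, compound 2 holds the lower one, and the step of a 2.8-fold lower number from compound 1 to compound 2 (0.44 log units; beyond the scatter) lies beyond the usual scatter. The third compound sits at the limit described by the limit of > 100000 nM in this assay, at which 1 of the 3 values shown sits. Compound 4, `COc1cc2c(Nc3ccc(C#N)cc3)ncnc2cc1OCCCN1CCN(c2ccncc2)CC1`, has not yet been measured. It differs from compound 2 in one place: 4-(pyridin-4-yl)piperazin-1-yl in place of pyrrolidin-1-yl on a saturated chain carbon, three bonds along the chain from an oxygen on an aromatic ring.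

Two measured steps speak to this change. The step of a 2.8-fold lower number from compound 1 to compound 2 (0.44 log units; beyond the scatter) shows that pyrrolidin-1-yl gave a lower number than dimethylamino at this position. The step of an at least 4.5-fold higher number from compound 2 to compound 3 (0.66 log units; beyond the scatter) shows that exchanging pyrrolidin-1-yl for a larger six-membered ring carrying a substituent gave a clearly higher number. The change to compound 4 is again an exchange of pyrrolidin-1-yl for a larger six-membered ring carrying a substituent, so a higher number is expected in this assay, of at least modest size, with a real chance that only a limit is reported. For compound 4 the expected value in this assay is 60000 nM, in the range 15000 nM to 200000 nM. That estimate means a step of a 2.8-fold higher number from compound 2 to compound 4 (0.44 log units; beyond the scatter), expected to weaken inhibition.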

Compound 4, half-maximal inhibitory concentration: 25500 nM
For compound 4 the middle estimate is 2.4-fold (0.37 log units) above the measured one; the range from low to high includes it.
By their numbers in this assay, from the lowest: compounds 2 and 4 (each within the scatter of the next); then compound 1. At a limit, above all of these: compound 3.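

In this assay, the step of a 1.2-fold higher number from compound 2 to compound 4 (0.07 log units; within the scatter) shows that the far larger 4-(pyridin-4-yl)piperazin-1-yl group cannot be told apart from pyrrolidin-1-yl at this position, so a bigger group on the chain does not by itself raise the number. The steps of an at least 3.9-fold lower number from compound 3 to compound 4 (0.59 log units; beyond the scatter) and a 2.4-fold lower number from compound 1 to compound 4 (0.38 log units; beyond the scatter) both favour compound 4, so the two larger six-membered ring groups part ways and what the ring holds counts, not its size alone. Compound 3 remains a limit of the assay and not a number: the limit of > 100000 nM in this assay, at which 1 of the 4 values shown sits.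

As far as these compounds go, it stays open whether the pyridine ring or the piperazine ring accounts for the difference from compound 3. A morpholin-4-yl or 4-methylpiperazin-1-yl group on the same chain would help to separate the two.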